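A few compounds are considered here, and "the series" means these few. Any claim that something is new, unique, unknown or untested is made for them only; others in the source may bear on it.

Measured in a functional assay on MCF7 cells (Homo sapiens) for antiproliferative activity, read by MTT assay, with a stated time of 24 h; on this read-out lower numbers stand for stronger inhibition and higher numbers for weaker inhibition:
- Compound 1 `CCn1c(C(=O)N[C@@H](C)C(=O)OC)ccc1C(CC)(CC)c1ccc(OCS(=O)(=O)c2ccccc2)c(C)c1`: 43700 nM
- Compound 2 `CCn1c(C(=O)NCCC(=O)OC)ccc1C(CC)(CC)c1ccc(OCS(=O)(=O)c2ccccc2)c(C)c1`: > 50000 nM, which is a limit of the assay

Among the compounds with values here, compound 1 holds the only actual number in this pair, so there is no measured value to rank it against.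

Next is compound 3 `CCn1c(C(=O)N[C@@H](CC(=O)OC)C(=O)OC)ccc1C(CC)(CC)c1ccc(OCS(=O)(=O)c2ccccc2)c(C)c1`, with the change methoxycarbonyl in place of hydrogen on a saturated chain carbon, two bonds along the chain from an amide-type nitrogen and a carbonyl carbon. This turns 1-(methoxycarbonyl)ethyl into 1,2-bis(methoxycarbonyl)ethyl.

Within the data shown here, only one measured step bears on this, and only indirectly, as it relocates the ester rather than adding a second one: an at least 1.1-fold higher number from compound 1 to compound 2 (0.05 log units; that floor lies within the scatter). That gives no sign of a real gain or loss, so no step beyond the scatter is expected in this assay. The estimate amounts to a 1.0-fold higher number from compound 1 to compound 3 (0.01 log units; within the scatter), an expected step within the scatter. A read-out at the limit of > 50000 nM in this assay, at which 1 of the 2 values shown sits, is also expected to be quite possible for compound 3. For compound 3 the estimated value is 45000 nM, with an expected range of 22000 nM to 90000 nM.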

Compound 3, half-maximal inhibitory concentration: > 50000 nM
Compound 3: a limit, no number; the forecaster's own chance of this, stated with the estimate: 50%; middle value at least 1.1-fold (0.04 log units) from the limit.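

In this assay compound 3 gives > 50000 nM, which is a limit of the assay. Methoxycarbonyl in place of hydrogen on the saturated chain carbon, two bonds along the chain from an amide-type nitrogen and a carbonyl carbon, gives an at least 1.1-fold higher number from compound 1 to compound 3 (0.05 log units; that floor lies within the scatter), so a second ester at this position brings no gain, although the true size of the step remains unresolved. The step between compound 2 and compound 3 cannot be read, and the series so far sits mostly at one edge of the read-out: the limit of > 50000 nM in this assay, at which 2 of the 3 values shown sit.

As far as these compounds go, whether a carboxylic acid in place of either methyl ester, or an amine or a longer chain on this saturated chain carbon, would bring a value clearly under the limit stays open. From the compounds shown here alone, how far compound 2 and compound 3 lie past their limits, and whether either truly differs from compound 1 by more than the scatter, also stays open.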